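Swapping the aryl group on compound 1 for an aminopyridine

The compounds below may be only part of what the source reports. "The series", "measured", "known", "first", "only" and "open" are said of these compounds alone.

Compound 1 `O=C(O)Cc1sc(C(c2ccc(F)cc2)c2ccc(F)cc2)nc1-c1ccc(Cl)cc1` gives 9.7 nM in an in vitro assay on HEK385-7 cells for displacement of a labelled ligand from prostaglandin D2 receptor 2 (Homo sapiens) (on this read-out lower numbers stand for stronger inhibition and higher numbers for weaker inhibition), the higher of the two numbers in hand; compound 2 `O=C(O)Cc1sc(C(c2ccccc2)c2ccccc2)nc1-c1cccc(F)c1` gives 2.9 nM, a number beyond the scatter below it. Compound 3 `O=C(O)Cc1sc(C(c2ccc(F)cc2)c2ccc(F)cc2)nc1-c1ccnc(N2CCC2)c1` is not yet measured and differs from compound 1 in one place: 2-(azetidin-1-yl)pyridin-4-yl in place of 4-chlorophenyl on an aromatic carbon. Among the measured compounds shown here, no measured pair shows this change, so its size is open. The author expects a modest weakening for compound 3, a 2.1-fold higher number from compound 1 to compound 3 (0.31 log units; beyond the scatter), since compound 1 already stands at 9.7 nM. Compound 3 is estimated at 20 nM, with a range from 5 nM to 80 nM.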

Compound 3, half-maximal inhibitory concentration: 660 nM
Estimate against measurement, compound 3: 33-fold (1.52 log units) below; measured number above the stated range.
By their numbers in this assay, from the lowest: compound 2; then compound 1; then compound 3.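

In this assay, among the compounds shown here, the step gives the first reading at this position, on the aromatic carbon next to the ring nitrogen: 2-(azetidin-1-yl)pyridin-4-yl in place of 4-chlorophenyl brings a 68-fold higher number from compound 1 to compound 3 (1.83 log units; beyond the scatter), a large weakening. The position therefore does not accept every aromatic group on the core of compound 1. No measurement at hand bears on why the number rises so far. Going by these compounds, the pyridine ring and the azetidine enter together, so their shares in the step stay open. An unsubstituted pyridin-4-yl, or a phenyl carrying the azetidine, would separate them.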